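Fluoro to methoxy on the aromatic ring

A few compounds are considered here, and "the series" means these few. Any claim that something is new, unique, unknown or untested is made for them only; others in the source may bear on it.

Measured in a physicochemical assay for solubility, read by HPLC, in phosphate buffer, with a stated time of 16 h, at pH 6.8; on this read-out lower numbers stand for lower solubility and higher numbers for higher solubility:
- compound 1 `Cc1ccc([C@H](C)NC(=O)Cn2nnc3ccccc3c2=O)cc1`: 12000 nM
- compound 2 `Cc1ccc([C@H](C)NC(=O)Cn2nnc3ccccc3c2=O)c(F)c1`: 4500 nM

Of these two compounds, compound 2 holds the lower number, at 4500 nM. The next structure is compound 3 `COc1cc(C)ccc1[C@H](C)NC(=O)Cn1nnc2ccccc2c1=O`, which has methoxy in place of fluoro on an aromatic carbon, ortho to a large group and meta to a methyl group: methoxy in place of fluoro on an aromatic carbon.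

Within the data shown here, only one measured step touches this aromatic carbon: a 2.7-fold lower number from compound 1 to compound 2 (0.43 log units; beyond the scatter). That step is modest and is fluoro in place of hydrogen. Among the measured compounds shown here, no measured compound carries methoxy, so the data give no direct reading on this change, and a single step cannot set a direction for it. No step beyond the scatter is therefore expected in this assay, and the range is kept wide on both sides. The expected change is a 1.1-fold lower number from compound 2 to compound 3 (0.05 log units; within the scatter). For compound 3 the estimated value is 4000 nM, with an expected range from 1500 nM to 11000 nM.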

Compound 3, solubility: 6900 nM
The estimate for compound 3 lay 1.7-fold (0.24 log units) below the measured number, and the stated range covers the measured number.
By their numbers in this assay, from the lowest: compounds 2, 3 and 1 (each within the scatter of the next, the first and the last beyond it).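

In this assay, methoxy in place of fluoro on this aromatic carbon gives a 1.5-fold higher number from compound 2 to compound 3 (0.19 log units; within the scatter) and methoxy in place of hydrogen at the same carbon gives a 1.7-fold lower number from compound 1 to compound 3 (0.24 log units; within the scatter) in the same read-out. Compound 3 therefore cannot be separated from either compound 1 or compound 2, even though the fluoro step a 2.7-fold lower number from compound 1 to compound 2 (0.43 log units; beyond the scatter) lies beyond the scatter, so the position now tolerates a second substituent, one with an added oxygen and an added hydrogen-bond acceptor, without a step that can be read as a change. Nothing measured on these compounds accounts for these numbers.

As far as these compounds go, how an amine, a carboxylic acid or a longer ether chain such as ethoxy would read on this aromatic carbon remains open, since fluoro and methoxy alone give only a narrow view of the position. Also open is whether these steps carry over when the methyl group on the same ring is replaced, as every compound shown keeps that group and the rest of the shared core unchanged.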